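The source may report more compounds than this note shows. Statements on the series, on what has been measured and on what is new or still open speak of the compounds shown alone.

Measured in an ADME assay on Vero cells (Chlorocebus sabaeus) for cytotoxicity, read by MTT assay, with a stated time of 48 h; a higher number here means a weaker inhibitor, a lower number a stronger inhibitor:
compound 1 `Cc1cccc(C(=O)OC2CCC(CN3CCN(c4cc(=O)c5cc(C(F)(F)F)cc([N+](=O)[O-])c5s4)CC3)CC2)c1`: > 64 ug/mL
compound 2 `CS(=O)(=O)OC1CCC(CN2CCN(c3cc(=O)c4cc(C(F)(F)F)cc([N+](=O)[O-])c4s3)CC2)CC1`: > 64 ug/mL
compound 3 `CC(C)C(=O)OC1CCC(CN2CCN(c3cc(=O)c4cc(C(F)(F)F)cc([N+](=O)[O-])c4s3)CC2)CC1`: > 64 ug/mL

Compound 1 gives > 64 ug/mL, which is a limit of the assay and not a number. The whole set stands the same way, at the limit of > 64 ug/mL in this assay, at which 3 of the 3 values shown sit.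

Compound 4 `O=C(OC1CCC(CN2CCN(c3cc(=O)c4cc(C(F)(F)F)cc([N+](=O)[O-])c4s3)CC2)CC1)C1CCC1` keeps the core of compound 1 and changes one group, with cyclobutyl in place of 3-methylphenyl on a carbonyl carbon.

The closest measured change is a step that the two limits leave unreadable from compound 1 to compound 3, where isopropyl takes the place of 3-methylphenyl on that same carbonyl carbon. The other two changes are a step that the two limits leave unreadable from compound 1 to compound 2 and a step that the two limits leave unreadable from compound 2 to compound 3, and both concern the whole (3-methylphenyl)carbonyl position on an oxygen on a saturated carbon. None of the three has a readable size. The best guide is compound 3, which carries isopropyl on the carbonyl carbon and gives > 64 ug/mL, again a limit.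

No step beyond the usual scatter is therefore expected in this assay, and no direction can be read from these data. The expected step is a step that the limit leaves unreadable from compound 1 to compound 4. The assay may well report only a limit once more. Compound 4 is estimated at 80 ug/mL, with an expected range of 40 ug/mL to 160 ug/mL.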

Compound 4, half-maximal inhibitory concentration: > 64 ug/mL
Compound 4 gave a limit, no number; the forecaster's own chance of this, stated with the estimate: 85%; the middle value does not contradict the limit.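

In this assay compound 4 gives > 64 ug/mL, which is a limit of the assay and not a number, so its steps from compound 1, compound 2 and compound 3 cannot be read. The whole set now stands together: the limit of > 64 ug/mL in this assay, at which 4 of the 4 values shown sit.

As far as these compounds go, whether the four compounds differ from one another at all in this assay stays open.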